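The compounds below may be only part of what the source reports. "The series", "measured", "known", "first", "only" and "open" are said of these compounds alone.

Compound 1 `CC1=C(C(=O)OC(C)(C)C)C(c2ccsc2)NC(=O)N1` and compound 2 `CC1=C(C(=O)OCc2ccccc2)C(c2ccsc2)NC(=O)N1` share one core and differ only in the group on an oxygen next to a carbonyl group. In an assay on membranes from CHO cells for displacement of a labelled ligand from adenosine receptor A1 (Homo sapiens), read by scintillation counting, with a stated time of 60 min, tested at 1 uM (a lower number here means less inhibition, a higher number more inhibition at the concentration tested (going by the name of the read-out)), compound 1 gives 15%, the lowest of the two numbers in hand, while compound 2 gives 57%. Among the compounds with values here, the one measured step, a number 42 percentage points higher from compound 1 to compound 2 (beyond the scatter), shows that changing the group on that oxygen can move the read-out a long way.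

Compound 3 `CC1=C(C(N)=O)C(c2ccsc2)NC(=O)N1` takes a different route from compound 1: amino in place of tert-butoxy on a carbonyl carbon. The ester of compound 1 thus becomes a primary amide in compound 3. The step from compound 1 to compound 2 bears on this only loosely, since it keeps the ester and swaps one alkyl group for another, whereas compound 3 removes the ester oxygen entirely. Within the data shown here, no measured pair tells how this assay responds to an amide at that carbonyl carbon, so the expected step of a number 5 percentage points higher from compound 1 to compound 3 (within the scatter) is small and uncertain in direction. Compound 3 is therefore estimated to give 20%, with a likely range from 0% to 50%.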

Compound 3, a percentage reported as inhibition, at one concentration (the size of the read-out at that concentration, not a potency): 2%
Compound 3: middle estimate off by 18 percentage points, on the high side; the range from low to high includes it.
By their numbers in this assay, from the lowest: compound 3; then compound 1; then compound 2.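

In this assay, putting amino in place of tert-butoxy on a carbonyl carbon gives a number 13 percentage points lower from compound 1 to compound 3 (beyond the scatter). The earlier step kept the ester and raised the read-out, while this one replaces the ester with a primary amide and lowers it, so changes at this carbonyl carbon can move the number in either direction from compound 1. No measurement in hand explains why this change lowers the read-out.

The change from compound 1 to compound 3 swaps a larger carbon-bearing group with an oxygen for a single nitrogen, so this one step cannot separate the effect of losing the tert-butoxy carbons from the effect of having nitrogen on the carbonyl carbon. An amide carrying a benzyl group on its nitrogen, or a methylamino group at the same place, would help to separate the two, and a carboxylic acid there would show how the read-out responds to a hydroxyl group on that carbonyl carbon.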